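This account rests on a few compounds, and the source may have more. Where it says the series, first, only, none or still open, it means among the compounds named here.

Values measured in an ADME assay on microsomes from liver (Homo sapiens) for metabolic stability, read by LC-MS, tested at 1 uM; on this read-out higher numbers stand for fast clearance and lower numbers for slow clearance:
- Compound 1 `NCCCOc1ccc([C@H]2CC[C@]3(CC2)OOC2(O3)C3CC4CC(C3)CC2C4)cc1`: < 7 mL.min-1.g-1 (a limit of the assay)
- Compound 2 `NCCOc1ccc([C@H]2CC[C@]3(CC2)OOC2(O3)C3CC4CC(C3)CC2C4)cc1`: < 7 mL.min-1.g-1 (a limit of the assay)
- Compound 3 `CC(C)(O)CNCCCOc1ccc([C@H]2CC[C@]3(CC2)OOC2(O3)C3CC4CC(C3)CC2C4)cc1`: 8 mL.min-1.g-1

Compound 3 is the only one of the three with a true number. Compound 1 and compound 2 both report a limit, (the limit of < 7 mL.min-1.g-1 in this assay, at which 2 of the 3 values shown sit).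

Compound 4 `c1cc([C@H]2CC[C@]3(CC2)OOC2(O3)C3CC4CC(C3)CC2C4)ccc1OC1CCNCC1` has not yet been measured. It differs from compound 3 as follows: piperidin-4-yl in place of 3-((2-hydroxy-2-methylpropyl)amino)propyl on an oxygen on an aromatic ring. In words, piperidin-4-yl stands in place of 3-((2-hydroxy-2-methylpropyl)amino)propyl on an oxygen on an aromatic ring.

Compound 4 lacks the 2-hydroxy-2-methylpropyl group, and so do compound 1 and compound 2, which makes the steps that add this group the closest guides. These are an at least 1.1-fold higher number from compound 1 to compound 3 (0.05 log units; that floor lies within the scatter) and an at least 1.1-fold higher number from compound 2 to compound 3 (0.05 log units; that floor lies within the scatter). Both floors lie within the scatter. The chain step gives no size: a step that the two limits leave unreadable from compound 1 to compound 2. Among the compounds with values here, no measured compound carries piperidin-4-yl, so the ring itself remains untested.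

On the two readable steps, no shift beyond the scatter is expected in this assay, and the expected step is a 1.1-fold lower number from compound 3 to compound 4 (0.06 log units; within the scatter). The assay may again report only a limit. The estimated value for compound 4 is 7 mL.min-1.g-1, with an expected range from 4 mL.min-1.g-1 to 15 mL.min-1.g-1.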

Compound 4, intrinsic clearance in microsomes: 15 mL.min-1.g-1
The estimate for compound 4 lay 2.1-fold (0.33 log units) below the measured number; low and high end bracket the measured number.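

In this assay, piperidin-4-yl on the oxygen on an aromatic ring gives the only steps among these compounds printed as beyond the scatter, measured against the open chains of compound 1 and compound 2 (an at least 2.1-fold higher number from compound 2 to compound 4 (0.33 log units; beyond the scatter); an at least 2.1-fold higher number from compound 1 to compound 4 (0.33 log units; beyond the scatter)). Against the longer chain carrying 2-hydroxy-2-methylpropyl, the change stays within the scatter (a 1.9-fold higher number from compound 3 to compound 4 (0.27 log units; within the scatter)), so compound 3 and compound 4 cannot be told apart at this position, although one carries an open chain and the other a six-membered non-aromatic ring. The two steps beyond the scatter are floors and not full sizes, because compound 1 and compound 2 each report a limit of the assay and not a number: the limit of < 7 mL.min-1.g-1 in this assay, at which 2 of the 4 values shown sit.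

The compounds shown leave open how large those two steps really are, and whether the ring itself matters or any substituent on the amine nitrogen would read the same. They also leave open whether pyrrolidin-3-yl, or 1-(2-hydroxy-2-methylpropyl)piperidin-4-yl, on the same oxygen would read like compound 4 or fall back to the limit seen for compound 1 and compound 2.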